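The source may hold more compounds than are shown below. What is called first, only, known or untested is meant among the compounds shown, and "the series" means these compounds.

Compound 1, whose structure is `Cc1c(O)ccc2c1[C@H](Cn1cc(-c3ccc(F)cc3)nn1)[C@@]13CC(=O)[C@@](C)(CC[C@@H]21)C3`, was tested in a functional assay on HL-60 cells (Homo sapiens) for cytotoxicity, read by MTT assay, with a stated time of 4 days; a lower number here means a stronger inhibitor, a higher number a weaker inhibitor. In this assay compound 1 gives only > 20000 nM, which is a limit of the measurement and not a number. This puts compound 1 at the edge of what the assay can report, as the limit of > 20000 nM in this assay, at which 1 of the 3 values shown sits, shows. Two further compounds that share the same core but differ in several places were measured in this assay. Compound 2, with structure `C=C1C[C@]23C[C@@]1(O)CC[C@H]2c1cc(Br)c(O)c(C)c1[C@@H]3Cn1cc(-c2ccc(Cl)cc2)nn1`, gives 5590 nM. Compound 3, with structure `C=C1C(=O)[C@]23C[C@@]1(O)CC[C@H]2c1ccc(O)c(C)c1[C@@H]3Cn1cc(-c2ccc(C(F)(F)F)cc2)nn1`, gives 720 nM. No single-change step between any two of these measured compounds is shown, so their values can only be read side by side.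

Compound 4, with structure `Cc1c(O)ccc2c1[C@H](Cn1cc(-c3ccc(C(F)(F)F)cc3)nn1)[C@@]13CC(=O)[C@@](C)(CC[C@@H]21)C3`, has not yet been measured. It differs from compound 1 in one place: trifluoromethyl in place of fluoro on an aromatic carbon. Compound 3, which also carries a trifluoromethyl group on that ring, gives 720 nM, but its core differs from that of compound 1 in other places as well, so that value does not settle the question.

For compound 4 a modest gain in this assay is expected, a step of an at least 1.3-fold lower number from compound 1 to compound 4 (0.12 log units; that floor lies within the scatter), though the starting point is a limit and the gain may not lift it clear of that limit. The estimate for compound 4 is 15000 nM, within a range from 3000 nM to 40000 nM.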

Compound 4, half-maximal inhibitory concentration: > 20000 nM
Compound 4: no number, only a limit; the forecaster's own chance of this, stated with the estimate: 50%; at least 1.3-fold (0.12 log units) between middle value and limit.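

In this assay compound 4 gives > 20000 nM as a limit and not a number. Within the data shown here, compound 1 also stands at a limit, so no step between compound 1 and compound 4 can be read: the limit of > 20000 nM in this assay, at which 2 of the 4 values shown sit. As far as these compounds go, whether trifluoromethyl in place of fluoro changes the value on the core of compound 1 at all stays open.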